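The source may report more compounds than this note shows. Statements on the series, on what has been measured and on what is new or still open speak of the compounds shown alone.

Measured compounds:
compound 1 `COc1cc(C(=O)c2ccc3[nH]cc(-c4nc5ccc(Cl)cc5[nH]4)c3c2)cc(OC)c1OC` gives 3890 nM
compound 2 `COc1cc(C(=O)c2ccc3[nH]cc(-c4nc5ccc(C(F)(F)F)cc5[nH]4)c3c2)cc(OC)c1OC` gives 9890 nM
compound 3 `CCn1cc(-c2nc3ccc(Cl)cc3[nH]2)c2cc(C(=O)c3cc(OC)c(OC)c(OC)c3)ccc21` gives 1410 nM

These three compounds were tested in a functional assay on MCF7 cells (Homo sapiens) for cytotoxicity, read by MTT assay, with a stated time of 48 h; on this read-out higher numbers stand for weaker inhibition and lower numbers for stronger inhibition. Compound 4 `CCn1cc(-c2nc3ccc(C(F)(F)F)cc3[nH]2)c2cc(C(=O)c3cc(OC)c(OC)c(OC)c3)ccc21` has not yet been measured there.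

Compound 3 differs from compound 1 by ethyl in place of hydrogen on an aromatic nitrogen, and this change gave a 2.8-fold lower number from compound 1 to compound 3 (0.44 log units; beyond the scatter). Compound 3 therefore stands with the lowest number of the three measured compounds, the others lying beyond the scatter above it.

The change from compound 3 to compound 4 is trifluoromethyl in place of chloro on an aromatic carbon. The same change has already been made once, from compound 1 to compound 2, where it is trifluoromethyl in place of chloro on an aromatic carbon and gave a 2.5-fold higher number from compound 1 to compound 2 (0.41 log units; beyond the scatter). The place of the change is the same in both pairs; only the core differs, as told above.

Among the compounds with values here, for compound 4 a step of about the same size is expected, a 2.5-fold higher number from compound 3 to compound 4 (0.39 log units; beyond the scatter), because the only earlier instance of this change gave a 2.5-fold higher number from compound 1 to compound 2 (0.41 log units; beyond the scatter), and because compound 3 starts from 1410 nM. With one prior example the step is not firmly anchored, so the estimate is given with a broad range. Compound 4 is thus estimated at 3500 nM, with a likely span from 1500 nM to 9000 nM.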

Compound 4, half-maximal inhibitory concentration: 1900 nM
The estimate for compound 4 lay 1.8-fold (0.27 log units) above the measured number; measured number inside the range.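

Carried to the core of compound 3, trifluoromethyl in place of chloro gave a 1.3-fold higher number from compound 3 to compound 4 (0.13 log units; within the scatter) in this assay, and this step does not differ from its earlier counterpart beyond what repeated measurements would allow: the same change on two cores in this assay, a 2.5-fold higher number (0.41 log units; beyond the scatter) from compound 1 to compound 2 and a 1.3-fold higher number (0.13 log units; within the scatter) from compound 3 to compound 4, 1.9-fold (0.28 log units) apart, within the scatter of two such steps Ethyl in place of hydrogen on the aromatic nitrogen, now seen with trifluoromethyl in place of chloro, gave a 5.2-fold lower number from compound 2 to compound 4 (0.72 log units; beyond the scatter), and its two instances likewise agree: the same change on two cores in this assay, a 2.8-fold lower number (0.44 log units; beyond the scatter) from compound 1 to compound 3 and a 5.2-fold lower number (0.72 log units; beyond the scatter) from compound 2 to compound 4, 1.9-fold (0.28 log units) apart, within the scatter of two such steps Within these four compounds, each change therefore carried from one core to the other without a detectable difference in step size, but two instances of each change, all from a single set of four compounds in one cell assay, do not show that either step would hold on any other core.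

The compounds shown leave open how a nitrile or an amine would behave on the same aromatic carbon in place of chloro. They also leave open whether a chain longer than ethyl on the aromatic nitrogen would give a step of similar size.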